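The source may report more compounds than this note shows. Statements on the series, on what has been measured and on what is new or still open speak of the compounds shown alone.

In a functional assay on CCRF-CEM cells (Homo sapiens) for cytotoxicity, read by cell counting, with a stated time of 3 days (a lower number here means a stronger inhibitor, a higher number a weaker inhibitor), compound 2 `C=C(Br)C(=O)Nc1cccc(/C=C2\SC(=O)N(Cc3ccc(C(F)(F)F)cc3)C2=O)c1` gives 920 nM, the lower of the two numbers recorded so far; compound 1 `Nc1cccc(/C=C2\SC(=O)N(Cc3ccc(F)cc3)C2=O)c1` gives 87000 nM, a gap well beyond the scatter. Compound 3 `Nc1cccc(/C=C2\SC(=O)N(Cc3ccc(C(F)(F)F)cc3)C2=O)c1` has not yet been measured. It differs from compound 2 by hydrogen in place of (1-bromoethenyl)carbonyl on a nitrogen on an aromatic ring. Among the measured compounds shown here, no measured pair shows this change on its own, but compound 1 carries the same free amino group and in this assay gives 87000 nM. A large step toward weaker inhibition is therefore expected a 65-fold higher number from compound 2 to compound 3 (1.81 log units; beyond the scatter). Compound 3 is estimated at 60000 nM, with a range from 15000 nM to 200000 nM.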

Compound 3, half-maximal inhibitory concentration: > 250000 nM
Compound 3: a limit, no number; the forecaster's own chance of this, stated with the estimate: 20%; middle value at least 4.1-fold (0.61 log units) from the limit.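

In this assay compound 3 stands at a limit of the assay, not at a number: the limit of > 250000 nM in this assay, at which 1 of the 3 values shown sits. Hydrogen in place of (1-bromoethenyl)carbonyl on the nitrogen gives an at least 270-fold higher number from compound 2 to compound 3 (2.43 log units; beyond the scatter), so this pair now shows directly, on one shared core, how much the number depends on that group. Trifluoromethyl in place of fluoro, with the free amino group kept, gives an at least 2.8-fold higher number from compound 1 to compound 3 (0.45 log units; beyond the scatter), so this change does not lower the number on its own.

The compounds shown leave open how much of the large step belongs to the bromine and how much to the carbonyl. An acetyl group on the same nitrogen would separate the two.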